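A few compounds are considered here, and "the series" means these few. Any claim that something is new, unique, unknown or untested is made for them only; others in the source may bear on it.

Measured compounds in a functional assay on MCF7 cells (Homo sapiens) for cytotoxicity, read by MTT assay, with a stated time of 24 h; on this read-out lower numbers stand for stronger inhibition and higher numbers for weaker inhibition:
compound 1, `Cc1cc(-c2nc3cc(F)ccc3o2)ccc1NC(=O)CCl`, which gives only a limit, > 100000 nM.
compound 2, `Cc1cc(-c2nc3ccccc3o2)ccc1NC(=O)CN1CCN(CCCN(C)C)CC1`, which gives 11300 nM.
compound 3, `O=C(CCl)Nc1ccc(-c2nc3cc(F)ccc3o2)cc1`, which gives 3260 nM.

Compound 1 sits at the limit of > 100000 nM in this assay, at which 1 of the 3 values shown sits. The change from compound 1 to compound 3 is hydrogen in place of methyl on an aromatic carbon, and in this assay it makes an at least 30-fold lower number from compound 1 to compound 3 (1.48 log units; beyond the scatter). Compound 2 carries the same kind of change toward compound 4, `CN(C)CCCN1CCN(CC(=O)Nc2ccc(-c3nc4ccccc4o3)cc2)CC1`; that change is hydrogen in place of methyl on an aromatic carbon. The two places are not the same word for word: in the first the carbon is ortho to a ((chloromethyl)carbonyl)amino group and meta to a large group, in the second it is ortho to a large group and meta to a 1,3-benzoxazol-2-yl group, so the change is the same kind, not the same. The difference between the core of compound 1 and the core of compound 2 is not broken down here. Of the two numbers measured, compound 2 has the higher one, and compound 3 gives a lower number than compound 2.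

A step smaller than the earlier one is expected from compound 2 to compound 4, a 4.5-fold lower number from compound 2 to compound 4 (0.66 log units; beyond the scatter), resting on an at least 30-fold lower number from compound 1 to compound 3 (1.48 log units; beyond the scatter) from compound 1. Compound 4 is expected to give 2500 nM, estimated between 600 nM and 8000 nM.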

Compound 4, half-maximal inhibitory concentration: 23400 nM
Compound 4: the middle estimate sits 9.4-fold (0.97 log units) below what was measured, outside the stated range (above it).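

In this assay, hydrogen in place of methyl on an aromatic carbon gives a 2.1-fold higher number from compound 2 to compound 4 (0.32 log units; beyond the scatter), so on these two cores the change does not carry over in either size or direction: the same change on two cores in this assay, an at least 30-fold lower number (1.48 log units; beyond the scatter) from compound 1 to compound 3 and a 2.1-fold higher number (0.32 log units; beyond the scatter) from compound 2 to compound 4, at least 63-fold (1.80 log units) apart, beyond the scatter of two such steps

Compound 1 gives > 100000 nM, which is a limit and not a number, so the earlier step is bounded on one side only.

With just two pairs, the result does not show which part of the cores accounts for the gap, nor how the change would read on any further core.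

Open, going by these compounds, is how ethyl or methoxy on the same aromatic carbon would read on either core, which would show whether the result is particular to the swap between methyl and hydrogen. Also open, on these data alone, is whether the step on the core of compound 2 would hold with a carboxylic acid in place of the terminal dimethylamino group.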